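A few compounds are considered here, and "the series" means these few. Any claim that something is new, unique, unknown or untested is made for them only; others in the source may bear on it.

Measured compounds:
compound 1 `COc1ccc(C(=O)N(C)c2ccc3[nH]c(-c4n[nH]c5ccccc45)cc3n2)cc1`: 3320 nM
compound 2 `COc1cccc(C(=O)N(C)c2ccc3[nH]c(-c4n[nH]c5ccccc45)cc3n2)c1`: 1420 nM

Within the data shown here, in a functional assay on HL-60 cells (Homo sapiens) for antiproliferative activity, read by MTT assay, with a stated time of 72 h (on this read-out lower numbers stand for stronger inhibition and higher numbers for weaker inhibition), compound 2 holds the lower of the two numbers, the sole comparison being a 2.3-fold lower number from compound 1 to compound 2 (0.37 log units; beyond the scatter). Compound 3 `CN(C(=O)c1ccco1)c1ccc2[nH]c(-c3n[nH]c4ccccc34)cc2n1` differs from compound 2 by furan-2-yl in place of 3-methoxyphenyl on a carbonyl carbon. Among the measured compounds shown here, the only measured step exchanges one methoxyphenyl for another on the same carbonyl carbon and bears on this change merely as a gauge of how much the amide aryl part can shift the number; no measured step swaps the aryl for a different ring. The step of a 1.5-fold higher number from compound 2 to compound 3 (0.19 log units; within the scatter) is therefore expected to be modest, with its direction uncertain. Compound 3 is estimated at 2200 nM (range 700 nM to 7000 nM).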

Compound 3, half-maximal inhibitory concentration: 4540 nM
For compound 3 the middle estimate is 2.1-fold (0.31 log units) below the measured one; the measured number falls inside the stated range.
By their numbers in this assay, from the lowest: compound 2; then compounds 1 and 3 (each within the scatter of the next).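

In this assay, replacing the aryl group with a smaller aromatic ring has an effect that depends on the reference compound: a 3.2-fold higher number from compound 2 to compound 3 (0.50 log units; beyond the scatter) is beyond the scatter, while a 1.4-fold higher number from compound 1 to compound 3 (0.14 log units; within the scatter) stays within it. On this carbonyl carbon, furan-2-yl therefore stands level with 4-methoxyphenyl, and only 3-methoxyphenyl is set apart from the other two groups. Nothing available here accounts for that difference.

Open, going by these compounds, is how a piperidine or an open alkyl chain on the carbonyl carbon would compare. On these data alone, compound 2 gives 1420 nM, and also open is whether any group here can go lower.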